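The source may hold more compounds than are shown below. What is called first, only, known or untested is meant among the compounds shown, and "the series" means these compounds.

Measured so far:
Compound 1, `COc1ccc(/C=C/S(=O)(=O)Cc2ccc(OC)cc2)cc1`, reaches only a limit of > 20000 nM in a functional assay on H157 cells (Homo sapiens) for antiproliferative activity, read by trypan blue exclusion; on this read-out higher numbers stand for weaker inhibition and lower numbers for stronger inhibition.
Compound 2, `COc1ccc(CS(=O)(=O)/C=C/c2ccc(F)cc2OC)cc1`, gives 20000 nM in this assay.

Compound 2 is the only one of the two measured compounds with an actual number in this assay; the value of compound 1 is a limit, (the limit of > 20000 nM in this assay, at which 1 of the 2 values shown sits), so no order between the two can be read from these figures.

Compound 3, `COc1ccc(CS(=O)(=O)/C=C/c2ccc(OC)cc2OC)cc1`, has not yet been measured. It differs from compound 2 in one place: methoxy in place of fluoro on an aromatic carbon, on a six-membered aromatic ring of carbon only, meta to a methoxy group and para to a large group. Within the data shown here, no measured pair shows this change, so the size of the step it brings in this assay is not known from the data. Both measured compounds sit at the weak end of the read-out, and nothing here points to a turn in either direction. The expected step from compound 2 to compound 3 is no change at the digits printed from compound 2 to compound 3 (within the scatter), nothing beyond the scatter. Compound 3 is therefore expected to give 20000 nM, between 6000 nM and 60000 nM, with a real chance that the assay again reports only a limit.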

Compound 3, half-maximal inhibitory concentration: > 20000 nM
Compound 3: no number, only a limit (the forecaster's own chance of this, stated with the estimate: 60%); the middle value sits exactly at the limit.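

Compound 3 reaches only a limit in this assay, > 20000 nM. Going by these compounds, with methoxy in place of fluoro on this aromatic carbon, meta to a methoxy group and para to a large group, the read-out gives a number no lower from compound 2 to compound 3 (the limit leaves the size open), so this change shows no sign of stronger inhibition, although how far the true value lies from that of compound 2 stays unknown. The step from compound 1 to compound 3 cannot be read, because both compounds give limits rather than numbers: the limit of > 20000 nM in this assay, at which 2 of the 3 values shown sit.

Fluoro and methoxy are the only groups compared at this position, so it remains open what a chloro group, a hydroxyl group or an amine would do there. The compounds shown also leave open whether any change to the shared core can bring a number clearly lower than the one for compound 2, which would give later steps a measurable size.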